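The compounds below may be only part of what the source reports. "The series", "measured", "known", "first", "only" and "open" are said of these compounds alone.

Compound 1 `COc1ccc(S(=O)(=O)c2nc3ccccc3nc2N2CCCC2)cc1` and compound 2 `O=S(=O)(c1ccc(Br)cc1)c1nc2ccccc2nc1N1CCCC1` share one core and differ only in bromo in place of methoxy on an aromatic carbon. In a functional assay on PC-3 cells (Homo sapiens) for cytotoxicity, read by MTT assay, with a stated time of 72 h (a lower number here means a stronger inhibitor, a higher number a weaker inhibitor), compound 1 gives a value of > 50000 nM, which is a limit of the assay rather than a number. In this assay compound 2 likewise gives > 50000 nM, again a limit. The step between them, a step that the two limits leave unreadable from compound 1 to compound 2, therefore cannot be read, and the pair shows only that both sit at the limit of > 50000 nM in this assay, at which 2 of the 3 values shown sit.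

Compound 3 `COc1ccc(S(=O)(=O)c2nc3ccccc3nc2N2CCCC(O)C2)cc1` keeps the 4-methoxyphenyl portion of compound 1 but differs in the core, namely (3-hydroxypiperidin-1-yl in place of pyrrolidin-1-yl on an aromatic carbon). In this assay, for the measured compounds named here, compound 3 gives 3410 nM, the only plain number among the three measured compounds. The step of an at least 14-fold lower number from compound 1 to compound 3 (1.16 log units; beyond the scatter) is large and beyond the scatter.

Compound 4 `O=S(=O)(c1ccc(Br)cc1)c1nc2ccccc2nc1N1CCCC(O)C1` has not yet been measured in this assay. It differs from compound 3 in bromo in place of methoxy on an aromatic carbon, which is the same change as that made from compound 1 to compound 2: the two places are described in identical words, on an aromatic carbon of a six-membered aromatic ring of carbon only, para to a large group. Whether that change helps or hurts is not known, since compound 1 and compound 2 both sit at the limit of > 50000 nM in this assay, at which 2 of the 3 values shown sit. The expectation for compound 4 therefore rests mainly on compound 3 at 3410 nM, with a step of a 1.8-fold higher number from compound 3 to compound 4 (0.25 log units; within the scatter) expected. Compound 4 is estimated to fall at 6000 nM, between 1500 nM and 30000 nM.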

Compound 4, half-maximal inhibitory concentration: 3690 nM
For compound 4 the middle estimate is 1.6-fold (0.21 log units) above the measured one; measured number inside the range.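

In this assay the exchange of methoxy for bromo can now be read on the core carrying 3-hydroxypiperidin-1-yl, where the step is a 1.1-fold higher number from compound 3 to compound 4 (0.03 log units; within the scatter), so compound 3 and compound 4 cannot be told apart. The exchange of pyrrolidin-1-yl for 3-hydroxypiperidin-1-yl, now seen with bromo as well as methoxy on the aromatic ring, gives an at least 13-fold lower number from compound 2 to compound 4 (1.13 log units; beyond the scatter), and the two cases point the same way: the same change on two cores in this assay, an at least 14-fold lower number (1.16 log units; beyond the scatter) from compound 1 to compound 3 and an at least 13-fold lower number (1.13 log units; beyond the scatter) from compound 2 to compound 4; the limit leaves it open whether they differ This shows that the large step carried over between the two cores shown, but two cores make no general rule, the full size of each step stays unknown, and the step between the two pyrrolidin-1-yl compounds cannot be read.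

The compounds shown leave open whether the hydroxyl or the change of ring size accounts for the large step; a piperidin-1-yl without the hydroxyl, or a 3-hydroxypyrrolidin-1-yl, would separate the two. Also open, on these data alone, is how an amine or a carboxylic acid in place of that hydroxyl, or a fluoro or a methyl in place of the bromo, would read in this assay.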